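This account rests on a few compounds, and the source may have more. Where it says the series, first, only, none or still open, it means among the compounds named here.

Compound 1 `CC1(C)[C@H](C(=O)OC(c2ccccc2)c2ccccc2)N2C(=O)/C(=C/C(=O)c3ccccc3)[C@H]2S1(=O)=O` — in a functional assay on A-375 cells (Homo sapiens) for cytotoxicity, read by MTT assay, with a stated time of 48 h (a lower number here means a stronger inhibitor, a higher number a weaker inhibitor), compound 1 gives 17500 nM.
Compound 2 `CC1(C)S[C@@H]2C/C(=C\C(=O)c3ccccc3)C(=O)N2[C@H]1C(=O)OC(c1ccccc1)c1ccccc1` — compound 2 gives only > 100000 nM, which is a limit of the assay and not a number.

For the measured compounds named here, compound 1 thus holds the only measured number in this set; compound 2 sits at the limit of > 100000 nM in this assay, at which 1 of the 2 values shown sits. Going by the values given here, no step between two measured compounds is available, so nothing here shows how a change on the aromatic ring of the benzoyl group shifts the read-out. Compound 3 `CC1(C)[C@H](C(=O)OC(c2ccccc2)c2ccccc2)N2C(=O)/C(=C/C(=O)c3ccc([N+](=O)[O-])cc3)[C@H]2S1(=O)=O` differs from compound 1 by nitro in place of hydrogen on an aromatic carbon. Among the compounds with values here, with no measured step to lean on, the step from compound 1 to compound 3 is expected to stay within the usual scatter, if anything leaning toward a somewhat stronger inhibitor. Compound 3 is therefore estimated at 10000 nM, between 3000 nM and 40000 nM. That expectation corresponds to a 1.8-fold lower number from compound 1 to compound 3 (0.24 log units; within the scatter).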

Compound 3, half-maximal inhibitory concentration: 76700 nM
For compound 3 the middle estimate is 7.7-fold (0.88 log units) below the measured one, and the stated range ends below it.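

The benzoyl ring of compound 1 proves not to be a silent site: in this assay, nitro in place of hydrogen on an aromatic carbon, para to a large group, gives a 4.4-fold higher number from compound 1 to compound 3 (0.64 log units; beyond the scatter). For the compounds shown here, this is the first measured step in the set, and it shows that this change moves the read-out toward a weaker inhibitor, by a modest amount. It is a single step with a single group, so it gives a direction for nitro at this place and no trend. Nothing shown here accounts for the direction of this step.

On these data alone, whether an amine, a methoxy group or a chlorine atom at the same place would also weaken compound 1 remains open. So does whether a carboxylic acid there would move the number the other way.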